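A few compounds are considered here, and "the series" means these few. Any claim that something is new, unique, unknown or untested is made for them only; others in the source may bear on it.

Compound 1 `Fc1cncc(-c2nc3cc(F)c(Cl)cc3n2C2CC2)c1` stands at the lowest of the three numbers in an assay on V79 cells for inhibition of cytochrome P450 11B2, mitochondrial (Homo sapiens), read by HTRF, with a stated time of 1 h (a lower number here means a stronger inhibitor, a higher number a weaker inhibitor), with 0.8 nM. The nearest is compound 3 `Cc1ccncc1-c1nc2cc(F)c(F)cc2n1C1CC1`, which gives 10.2 nM, a gap beyond the scatter. Furthest is compound 2 `Fc1cccc2nc(-c3cccnc3)n(C3CC3)c12`, which gives 107 nM, also beyond the scatter. For the measured compounds named here, no two measured compounds differ in only one place, so no single-change step among them can be read. Compound 4 `N#Cc1cc2c(cc1F)nc(-c1cncc(F)c1)n2C1CC1` is not yet measured; it differs from compound 1 by cyano in place of chloro on an aromatic carbon. Going by the values given here, with no comparable step in hand, the expected step in this assay is a 1.9-fold higher number from compound 1 to compound 4 (0.27 log units; within the scatter), a small move toward a higher number, at the edge of the scatter. Compound 4 is expected to give 1.5 nM, within 0.5 nM to 5 nM.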

Compound 4, half-maximal inhibitory concentration: 1 nM
Estimate against measurement, compound 4: 1.5-fold (0.18 log units) above; measured number inside the range.
By their numbers in this assay, from the lowest: compounds 1 and 4 (each within the scatter of the next); then compound 3; then compound 2.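

In this assay, the series gains its first single-change step, a 1.3-fold higher number from compound 1 to compound 4 (0.10 log units; within the scatter), with cyano in place of chloro on an aromatic carbon ortho to a fluoro group. The two groups cannot be told apart at this position, although cyano adds a heavy atom and a hydrogen-bond acceptor. No measurement bears on why they read alike. From the compounds shown here alone, whether an amine, a carboxylic acid or a longer chain would be accepted at this position remains open. Going by these compounds, the exchange is also read only on the core of compound 1, so its effect on other cores is unknown.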